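The source may hold more compounds than are shown below. What is called first, only, known or untested is meant among the compounds shown, and "the series" means these compounds.

Working notes on the tetrabromobenzotriazole series. Compound 1 `OCC(O)Cn1nc2c(Br)c(Br)c(Br)c(Br)c2n1` gives 56% in a functional assay on CCRF-CEM cells (Homo sapiens) for antiproliferative activity, read by MTT assay, with a stated time of 48 h, tested at 25 uM; on this read-out lower numbers stand for a stronger effect and higher numbers for a weaker effect at the one concentration tested. Compound 2 `OC(CCn1nc2c(Br)c(Br)c(Br)c(Br)c2n1)c1ccccc1` gives 84% in this assay, and compound 3 `OC(CCn1nc2c(Br)c(Br)c(Br)c(Br)c2n1)c1cccc(Cl)c1` gives 68%. Compound 1 therefore stands lowest of the three numbers; compound 3 is nearest and compound 2 furthest, both gaps beyond the scatter. For the measured compounds named here, the only step between two compounds differing in a single place is a number 16 percentage points lower from compound 2 to compound 3 (beyond the scatter), chloro in place of hydrogen on an aromatic carbon, a modest move toward a stronger effect.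

Compound 4 `CC(O)CCn1nc2c(Br)c(Br)c(Br)c(Br)c2n1` is not yet measured. It differs from compound 1 by 2-hydroxypropyl in place of 1,2-dihydroxyethyl on a saturated chain carbon bound to an aromatic nitrogen. Going by the values given here, no measured step bears on this part of the molecule: the one step recorded concerns an aromatic carbon and leaves the chain untouched. Among the compounds with values here, compounds 2 and 3 carry a different chain and give higher numbers than compound 1, but no single-place step connects either of them to compound 1, so their values show only that the chain can be varied without losing the read-out entirely. On these grounds no step beyond the scatter is expected in this assay, in either direction, and the uncertainty is wide. Compound 4 is expected to give 62%, in a range from 42% to 82%. That estimate means an expected step of a number 6 percentage points higher from compound 1 to compound 4 (within the scatter).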

Compound 4, a percentage reported as activity, at one concentration (the size of the read-out at that concentration, not a potency): 86%
Estimate against measurement, compound 4: 24 percentage points below, outside the stated range (above it).
By their numbers in this assay, from the lowest: compound 1; then compound 3; then compounds 2 and 4 (each within the scatter of the next).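

In this assay, for the compounds shown here, the chain place proves responsive, which the earlier step on an aromatic carbon could not show: 2-hydroxypropyl in place of 1,2-dihydroxyethyl, on a saturated chain carbon bound to an aromatic nitrogen, gives a number 30 percentage points higher from compound 1 to compound 4 (beyond the scatter) in the first single-place reading on this part of the molecule. The 4 heavy atoms stay, while 1 hydrogen-bond donor and 1 hydrogen-bond acceptor replace 2 of each, so this pair ties the lower number of compound 1 to the 1,2-dihydroxyethyl group alone. Going by these compounds alone, on a saturated chain carbon bound to an oxygen on a saturated carbon and a saturated chain carbon, methyl in place of 3-chlorophenyl gives a number 18 percentage points higher from compound 3 to compound 4 (beyond the scatter) while methyl in place of phenyl gives a number 2 percentage points higher from compound 2 to compound 4 (within the scatter) and so does not separate the two groups, leaving the chloro-bearing ring as the one group at this place that stands apart.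

Still open, going by these compounds, is what an amine or a carboxylic acid at the chain end, or a longer chain, would give on the shared core. Nothing available explains any of these steps.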